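The source may report more compounds than this note shows. Statements on the series, on what has been measured and on what is new or still open speak of the compounds shown alone.

Among the measured compounds shown here, compound 3 `CN(C)CCn1cnnc1-c1cc(Oc2ccc(NC(=O)N/N=C/c3ccc(F)cc3F)cc2F)ccn1` shows the lowest of the three numbers so far in a functional assay on U-87MG ATCC cells (Homo sapiens) for cytotoxicity, read by MTT assay, with a stated time of 72 h (on this read-out lower numbers stand for stronger inhibition and higher numbers for weaker inhibition), giving 1900 nM, although the step of a 1.2-fold lower number from compound 2 to compound 3 (0.08 log units; within the scatter) lies within the scatter. Compound 2 `CN(C)CCn1cnnc1-c1cc(Oc2ccc(NC(=O)N/N=C/c3ccc(F)cc3)cc2F)ccn1` gives 2310 nM in this assay. Compound 1 `CN(C)CCn1cnnc1-c1cc(Oc2ccc(NC(=O)N/N=C/c3ccccc3O[N+](=O)[O-])cc2F)ccn1` gives 7150 nM in this assay, and the step of a 3.8-fold lower number from compound 1 to compound 3 (0.58 log units; beyond the scatter) is beyond the scatter. Compound 4 `CN(C)CCn1cnnc1-c1cc(Oc2ccc(NC(=O)N/N=C/c3c(O)ccc4ccccc34)cc2F)ccn1` has not yet been measured; it differs from compound 3 by 2-hydroxynaphthalen-1-yl in place of 2,4-difluorophenyl on a carbon with a double bond to nitrogen. For the measured compounds named here, the steps that bear on this change are a 3.1-fold lower number from compound 1 to compound 2 (0.49 log units; beyond the scatter) and a 3.8-fold lower number from compound 1 to compound 3 (0.58 log units; beyond the scatter), in which a phenyl carrying an oxygen-linked substituent gave way to a fluorinated phenyl and the number fell modestly in both cases. The change to compound 4 runs the other way, putting a hydroxy-bearing naphthyl in place of a fluorinated phenyl, so a modest step toward a higher number is expected in this assay, a 2.4-fold higher number from compound 3 to compound 4 (0.37 log units; beyond the scatter). For compound 4 the estimate in this assay is 4500 nM, with a range from 1500 nM to 14000 nM.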

Compound 4, half-maximal inhibitory concentration: 620 nM
Compound 4: middle estimate off by 7.3-fold (0.86 log units), on the high side; measured number below the stated range.
By their numbers in this assay, from the lowest: compound 4; then compounds 3 and 2 (each within the scatter of the next); then compound 1.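

In this assay, 2-hydroxynaphthalen-1-yl on a carbon with a double bond to nitrogen goes lower than both fluorinated phenyls, with a step (a 3.1-fold lower number from compound 3 to compound 4 (0.49 log units; beyond the scatter)) from the 2,4-difluorophenyl and another (a 3.7-fold lower number from compound 2 to compound 4 (0.57 log units; beyond the scatter)) from the 4-fluorophenyl. Until now, replacing 2-(nitrooxy)phenyl had given only modest steps, whereas this group gives the first large one (a 12-fold lower number from compound 1 to compound 4 (1.06 log units; beyond the scatter)), and it shows that a group with two aromatic rings and a hydroxy is accepted at this position. Nothing available explains this gain.

The compounds shown do not separate the part played by the hydroxy from that of the second aromatic ring, and a plain naphthalen-1-yl and a 2-hydroxyphenyl, which could do so, are not among them. Going by these compounds, whether a methoxy or an amine in place of the hydroxy would keep the lower number also remains open.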